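A few compounds are considered here, and "the series" means these few. Any claim that something is new, unique, unknown or untested is made for them only; others in the source may bear on it.

Compound 1 `O=C(Nc1nnc(-c2ccc(Cl)cc2)s1)c1ccccc1` — > 5010 nM
Compound 2 `Cc1cccc(C)c1C(=O)Nc1nnc(-c2ccc(Cl)cc2)s1` — 69.2 nM
Compound 3 `COc1cccc(OC)c1C(=O)Nc1nnc(-c2ccc(Cl)cc2)s1` — 58.9 nM

Compound 1 carries a plain benzamide on the shared core, and in a functional assay on the whole organism (integument) for inhibition, with Chilo suppressalis as the target, read by scintillation counting, with a stated time of 72 h (a lower number here means a stronger inhibitor, a higher number a weaker inhibitor), compound 1 reaches only a limit, (the limit of > 5010 nM in this assay, at which 1 of the 3 values shown sits), so no number is known for it. Compound 2 and compound 3 each give a number, and their values in this assay lie within the usual scatter of each other. Compound 4 `O=C(Nc1nnc(-c2ccc(Cl)cc2)s1)c1ccccc1Cl` differs from compound 1 by chloro in place of hydrogen on an aromatic carbon. Among the compounds with values here, no measured pair differs in just this one place, so the size of the step has to be judged from the three numbers at hand, and compound 1 offers only a limit. Compound 4 is expected to come in stronger than compound 1, the estimated step being an at least 16-fold lower number from compound 1 to compound 4 (1.22 log units; beyond the scatter). Compound 4 is thus estimated at 300 nM, plausibly between 80 nM and 2000 nM.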

Compound 4, half-maximal inhibitory concentration: > 5010 nM
Compound 4: a limit, no number; the forecaster's own chance of this, stated with the estimate: 15%; middle value at least 16-fold (1.22 log units) from the limit.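

Within the data shown here, compound 1 and compound 4 each reach only a limit in this assay, so no step between them can be read: the limit of > 5010 nM in this assay, at which 2 of the 4 values shown sit. The compounds shown leave open whether chloro in place of hydrogen on an aromatic carbon changes the potency of compound 1 at all.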